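The compounds below may be only part of what the source reports. "The series", "measured", "known", "first", "only" and "open" are said of these compounds alone.

Compound 1 `CCCCN(CC)c1nc(C)nc2c1nnn2-c1c(Cl)cc(OC)cc1OC`: in an in vitro assay on 293-EBNA cells for binding affinity to corticotropin-releasing factor receptor 1 (Homo sapiens) (on this read-out higher numbers stand for weaker inhibition and lower numbers for stronger inhibition), compound 1 gives 4.4 nM.
Compound 2 `CCCCC(CCCC)Nc1nc(C)nc2c1nnn2-c1ccc(C(C)C)cc1Br`: in this assay compound 2 gives 4.5 nM.
Compound 3 `CCN(CC)c1nc(C)nc2c1ncn2-c1ccc(C(C)C)cc1Br`: in this assay compound 3 gives 12.4 nM.

Among these three, compound 3 stands highest, and the gap to each of the other two lies beyond the scatter, so compound 3 is the weakest binder of the measured set. Compounds 1 and 2 lie within the scatter of each other, and nothing can be said about their order. Going by the values given here, no two measured compounds differ in only one place; compound 2 differs from compound 3 both in its core and in its amine, so its lower number cannot be assigned to either change alone.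

Compound 4 `CCCC(CCC)Nc1nc(C)nc2c1ncn2-c1ccc(C(C)C)cc1Br` differs from compound 3 in a single place: (1-propylbutyl)amino in place of diethylamino on an aromatic carbon. The step from compound 3 to compound 4 is estimated as a 2.5-fold lower number from compound 3 to compound 4 (0.39 log units; beyond the scatter), in the direction of a lower number, of a size expected to reach just beyond the scatter, since compound 2 with its own branched amine gives the lower value 4.5 nM while the change of core remains a confounder. Compound 4 is therefore expected to give 5 nM, with a range from 1.5 nM to 15 nM.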

Compound 4, inhibition constant: 3.6 nM
Compound 4: middle estimate off by 1.4-fold (0.14 log units), on the high side; low and high end bracket the measured number.
By their numbers in this assay, from the lowest: compounds 4, 1 and 2 (each within the scatter of the next); then compound 3.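

In this assay, going by these compounds alone, the exchange of diethylamino for (1-propylbutyl)amino gives a 3.4-fold lower number from compound 3 to compound 4 (0.54 log units; beyond the scatter), and this is the first change in the set that can be read on its own, with the core and the aryl group held constant. Within the data shown here, it shows that this position, on an aromatic carbon next to the ring nitrogen, responds to the choice of amine, which the earlier compounds could not show since each pair differed in more than one place. The change does several things at once: the group grows from 5 to 8 heavy atoms and gains a hydrogen-bond donor, and the pair cannot separate these differences. No measurement shown gives a reason for the step.

On these data alone, it remains open whether the gain follows the larger branched chain or the hydrogen on the amine nitrogen; dipropylamino, which has no such hydrogen, and (1-ethylpropyl)amino, with shorter branches, would help to tell these apart. As far as these compounds go, it is also open whether the same exchange would give a step of similar size on the core of compound 2.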